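The source may hold more compounds than are shown below. What is called first, only, known or untested is meant among the compounds shown, and "the series" means these compounds.

Measured compounds and their values:

Compound 1 `Cc1ccccc1-n1nc(C)c2c1NC(=O)[C@H](C)S[C@@H]2c1ccc(/C=C/c2ccccc2)cc1` was reported as "not active" (no number reported) in an assay on isolated protein for agonist activity at Bile acid receptor (Homo sapiens), read by AlphaScreen, with a stated time of 30 min (on this read-out higher numbers stand for an effect only at larger amounts of compound and lower numbers for an effect already at smaller amounts), with no number.
Compound 2 `Cc1nn(-c2ccccc2C(C)C)c2c1[C@@H](c1ccc(Oc3ccccc3)cc1)S[C@@H](C)C(=O)N2` gives 1900 nM in this assay.
Compound 3 `CCOc1cccc(-c2ccc([C@H]3S[C@@H](C)C(=O)Nc4c3c(C)nn4-c3ccccc3C)cc2)c1` gives 3500 nM in this assay.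

All three compounds share the same core and differ in the group hanging from the aromatic ring attached to it. Among the two compounds for which a number was reported, compound 3 carries the higher one, yet its gap to compound 2 is within the usual scatter of repeated measurements, so the two cannot be told apart, and compound 1 offers no number for comparison.

Compound 4 `COC(=O)c1ccc(-c2ccc([C@H]3S[C@@H](C)C(=O)Nc4c3c(C)nn4-c3ccccc3C)cc2)cc1` has not yet been measured. The change from compound 3 to compound 4 is 4-(methoxycarbonyl)phenyl in place of 3-ethoxyphenyl on an aromatic carbon.

Among the measured compounds shown here, no pair of measured compounds differs in just one place, so there is no step to lean on for this change. The two numbers that exist lie close together despite different groups at this position, and nothing points to a clear direction. The expectation is therefore a step of a 1.2-fold lower number from compound 3 to compound 4 (0.07 log units; within the scatter), that is, none beyond the scatter. Compound 4 is expected to give about 3000 nM in this assay, with a range from 800 nM to 12000 nM.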

Compound 4, half-maximal effective concentration: "not active" (no number reported)
No number was reported for compound 4, so the estimate cannot be set against anything.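

Among the compounds shown here, compound 4, like compound 1, was reported without a number, so no step from compound 3 to compound 4 can be read. Nothing measured here offers an explanation for this result. The compounds shown leave open how far 4-(methoxycarbonyl)phenyl and 3-ethoxyphenyl really differ in their effect on the receptor.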